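A stereochemical step taken at the assay limit

The source may report more compounds than this note shows. Statements on the series, on what has been measured and on what is new or still open speak of the compounds shown alone.

In an ADME assay for metabolic stability, read by HPLC, in simulated intestinal fluid, with a stated time of 12 h, at pH 6.8 (on this read-out higher numbers stand for a longer-lived compound and lower numbers for a shorter-lived compound), compound 1 (`O=C(O)[C@@H](CO)NC(=O)[C@H]1C[C@@H](O)CN1`) gives > 12 h as a limit of the assay and not a number. Compound 2 (`O=C(O)[C@@H](CO)NC(=O)[C@H]1C[C@H](O)CN1`) gives > 12 h as a limit too. Compound 3 (`O=C(O)[C@H](CO)NC(=O)[C@H]1C[C@@H](O)CN1`) gives > 12 h, again a limit. Compound 3 therefore stands with the other two at the limit of > 12 h in this assay, at which 3 of the 3 values shown sit, and has no finer rank.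

Compared with compound 3, compound 4 (`O=C(O)[C@H](CO)NC(=O)[C@@H]1C[C@H](O)CN1`) shows this difference: the two compounds have the same atoms and bonds and differ only in configuration as drawn: 2 of 3 stereo elements differ; a stereocentre at a saturated ring carbon is drawn R in compound 3 and S in compound 4; a stereocentre at a saturated ring carbon is drawn R in compound 3 and S in compound 4. No group leaves or enters.

Going by the values given here, three measured steps bear on this change: a step that the two limits leave unreadable from compound 1 to compound 2 and a step that the two limits leave unreadable from compound 1 to compound 3 and a step that the two limits leave unreadable from compound 2 to compound 3. Each is a change of configuration alone, and none has a readable size. They give no ground for expecting a shift in either direction in this assay, so no step beyond the usual scatter is expected, and another limit is the likely report. The expected step is a step that the limit leaves unreadable from compound 3 to compound 4. For compound 4 the estimate is 15 h, with an expected range from 12 h to 24 h.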

Compound 4, half-life in the ADME assay: > 12 h
Compound 4 was reported as a limit; the forecaster's own chance of this, stated with the estimate: 90%; the middle value is on the limit's open side.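

Compound 4 sits at the limit with compound 1, compound 2 and compound 3 in the ADME assay. In a physicochemical assay for metabolic stability, read by HPLC, in phosphate buffer, with a stated time of 12 h, at pH 7.2 (a higher number here means that the compound lasts longer, a lower number that the compound disappears faster), compound 3 gives > 12 h, a limit of the assay and not a number. In the physicochemical assay compound 4 gives > 12 h, again a limit. So no step to compound 4 can be read. The compounds shown leave open whether configuration changes the half-life at all.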